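The source may report more compounds than this note shows. Statements on the series, on what has been measured and on what is new or still open speak of the compounds shown alone.

Working notes on the series:

- compound 1 `Cc1cc(=O)c2c(O)c(CN3CCCC3)c(O)c([C@H]3CCN(C)C[C@H]3O)c2o1`: 22%
- compound 2 `Cc1cc(=O)c2c(O)c(CN3CCC(c4ccccc4)CC3)c(O)c([C@H]3CCN(C)C[C@H]3O)c2o1`: 21%
- compound 3 `Cc1oc2c([C@H]3CCN(C)C[C@H]3O)c(O)cc(O)c2c(=O)c1C(O)c1ccccc1Br`: 7%

All three values come from a functional assay on Caco-2 cells (Homo sapiens) for inhibition, read by MTT assay, with a stated time of 48 h, tested at 10 uM; on this read-out higher numbers stand for more inhibition of growth at the one concentration tested and lower numbers for less inhibition of growth. Compound 3 gives the lowest of the three numbers at 7%. Its nearest neighbour is compound 2 at 21% and its furthest is compound 1 at 22%, and both lie beyond the scatter from compound 3.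

Next in line is compound 4 `CCOc1ccc(Br)c(C(O)c2c(C)oc3c([C@H]4CCN(C)C[C@H]4O)c(O)cc(O)c3c2=O)c1`, which is compound 3 with a single change: ethoxy in place of hydrogen on an aromatic carbon. In words, this is ethoxy in place of hydrogen on an aromatic carbon, para to a bromo group, so that 2-bromophenyl becomes 2-bromo-5-ethoxyphenyl.

For the measured compounds named here, the series holds no measured pair differing in one place, so nothing shows directly what this change does in this assay. The measured numbers span only from compound 3 at 7% to compound 1 at 22%, and a result inside that span is the working expectation. No step beyond the scatter is expected, and any drift would more likely be upward. The estimated change is a number 3 percentage points higher from compound 3 to compound 4 (within the scatter). The expected value for compound 4 is 10%, with an estimated range of 2% to 22%.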

Compound 4, percent growth inhibition at one concentration: 5%
Compound 4: the middle estimate sits 5 percentage points above what was measured; low and high end bracket the measured number.
By their numbers in this assay, from the lowest: compounds 4 and 3 (each within the scatter of the next); then compounds 2 and 1 (each within the scatter of the next).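

In this assay, for the compounds shown here, ethoxy in place of hydrogen on an aromatic carbon, para to a bromo group, gives a number 2 percentage points lower from compound 3 to compound 4 (within the scatter) and so provides the first pair that differs in one place. At this position, the change from 2-bromophenyl to 2-bromo-5-ethoxyphenyl adds 3 heavy atoms and one hydrogen-bond acceptor without a step beyond the scatter, so this one change does not lift growth inhibition at the single concentration tested. Nothing available explains this outcome.

As far as these compounds go, whether a longer chain such as butoxy, an amine such as dimethylamino or a carboxylic acid at the same place would move the number beyond the scatter stays open. Also open, from the compounds shown here alone, is whether ethoxy on this aromatic ring would give a similar result in a compound carrying the side chain of compound 1 or compound 2, as the step is known only from compound 3.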